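From a carboxy chain to an ether chain

The source may report more compounds than this note shows. Statements on the series, on what has been measured and on what is new or still open speak of the compounds shown alone.

In a functional assay on FaDu cells (Homo sapiens) for cytotoxicity, read by MTT assay, with a stated time of 72 h (a higher number here means that more compound is tolerated, a lower number that less compound is tolerated), compound 3 (`COc1ccc(NC(=O)C(=O)c2cn(CCC(=O)O)c3ccccc23)cn1`) gives > 10000 nM, which is a limit and not a number. Compound 1 (`COc1ccc(NC(=O)C(=O)c2cn(CC(C)(C)OC)c3ccccc23)cn1`) also gives a limit, > 10000 nM. Compound 2 (`COc1ccc(NC(=O)C(=O)c2cn(C3CCCC3)c3ccccc23)cn1`) gives a true number, 370 nM.

Compound 4 (`COc1ccc(NC(=O)C(=O)c2cn(CCOC(C)C)c3ccccc23)cn1`) differs from compound 3 in its side chain: isopropoxy in place of carboxy on a saturated chain carbon, two bonds along the chain from an aromatic nitrogen. Two large measured steps bear on this change. One is an at least 27-fold higher number from compound 2 to compound 3 (1.43 log units; beyond the scatter), where the carboxy-bearing chain replaces cyclopentyl. The other is an at least 27-fold lower number from compound 1 to compound 2 (1.43 log units; beyond the scatter), which shows that a chain carrying an ether can also sit at the limit. A move to a lower number is therefore expected, but probably only part of the way towards compound 2.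

The estimated change is an at least 4.0-fold lower number from compound 3 to compound 4 (0.60 log units; beyond the scatter). Compound 4 is expected at 2500 nM, within an estimated range of 300 nM to 10000 nM.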

Compound 4, concentration lethal to 50% of the cells: 211 nM
For compound 4 the middle estimate is 12-fold (1.07 log units) above the measured one; measured number below the stated range.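

In this assay, an ether on the chain does not by itself leave a compound at the limit: isopropoxy in place of carboxy gives an at least 47-fold lower number from compound 3 to compound 4 (1.67 log units; beyond the scatter), and isopropoxymethyl in place of 1-methoxy-1-methylethyl gives an at least 47-fold lower number from compound 1 to compound 4 (1.67 log units; beyond the scatter). Both of these steps start from a limit and not a number: the limit of > 10000 nM in this assay, at which 2 of the 4 values shown sit. Cyclopentyl and 2-isopropoxyethyl cannot be told apart here, with a 1.8-fold lower number from compound 2 to compound 4 (0.24 log units; within the scatter).

The compounds shown leave open whether the chain oxygen matters at all, which a plain butyl chain would test. An amine at the chain end is also an open case.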